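A few compounds are considered here, and "the series" means these few. Any claim that something is new, unique, unknown or untested is made for them only; others in the source may bear on it.

In a functional assay on MOLT-4 cells (Homo sapiens) for inhibition, read by MTT assay, with a stated time of 72 h (a higher number here means a weaker inhibitor, a lower number a stronger inhibitor), compound 1 (`COc1cc(NC(C)CCCNC(=O)Nc2cccc(Cl)c2)c2ncccc2c1`) gives 21000 nM. Compound 2 (`COc1cc(NC(C)CCCNC(=O)NNC(=O)Nc2ccc(F)cc2)c2ncccc2c1`) gives only a limit, >= 250000 nM. Compound 3 (`COc1cc(NC(C)CCCNC(=O)NNC(=O)Nc2cccc(F)c2)c2ncccc2c1`) likewise gives only a limit, >= 250000 nM. Compound 4 (`COc1cc(NC(C)CCCNC(=O)Nc2cccc(C(F)(F)F)c2)c2ncccc2c1`) carries 3-(trifluoromethyl)phenyl in place of ((3-fluorophenyl)carbamoyl)amino on an amide-type nitrogen. Going by the values given here, two measured steps bear on this change, an at least 11-fold higher number from compound 1 to compound 2 (1.07 log units; beyond the scatter) and an at least 11-fold higher number from compound 1 to compound 3 (1.07 log units; beyond the scatter). Both are large, and both introduce a carbamoylamino group where compound 4 has none. A large step towards a lower number in this assay is therefore expected, with compound 4 returning close to compound 1 at 21000 nM. The expected step is an at least 12-fold lower number from compound 3 to compound 4 (1.09 log units; beyond the scatter). For compound 4 the estimated value is 20000 nM, within an expected range of 7000 nM to 60000 nM.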

Compound 4, half-maximal inhibitory concentration: 20000 nM
Estimate against measurement, compound 4: no gap at the digits printed; measured number inside the range.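

In this assay trifluoromethyl in place of chloro on an aromatic carbon gives a 1.1-fold lower number from compound 1 to compound 4 (0.02 log units; within the scatter) and leaves these two groups indistinguishable here. With 3-(trifluoromethyl)phenyl on the amide-type nitrogen, the series returns to the level of compound 1, with an at least 12-fold lower number from compound 3 to compound 4 (1.09 log units; beyond the scatter) and an at least 12-fold lower number from compound 2 to compound 4 (1.09 log units; beyond the scatter) as the steps from the fluorophenyl carbamoylamino compounds. Both steps start from a limit and not from a number: the limit of >= 250000 nM in this assay, at which 2 of the 4 values shown sit.

Going by these compounds, whether a carboxylic acid or an amine in place of chloro on the aromatic carbon would hold this level stays open. The limits also leave the steps between the 3-fluorophenyl and 4-fluorophenyl compounds unreadable.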